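The compounds below may be only part of what the source reports. "The series", "measured", "known", "first", "only" and "open" are said of these compounds alone.

Compound 1 `COc1ccccc1-c1cc(N2CCC(CNS(N)(=O)=O)CC2)ncn1` and compound 2 `NS(=O)(=O)NCC1CCN(c2cc(-c3ccccc3Cl)ncn2)CC1` share one core and differ in a single change, (chloro in place of methoxy on an aromatic carbon). In a functional assay on MCF7 cells (Homo sapiens) for antiproliferative activity, read by sulforhodamine B assay, with a stated time of 48 h (a higher number here means a weaker inhibitor of growth, a lower number a stronger inhibitor of growth), compound 1 gives 10100 nM, while compound 2 gives 62400 nM, so that a 6.2-fold higher number from compound 1 to compound 2 (0.79 log units; beyond the scatter). Compound 3 `COc1ccc(-c2cc(N3CCC(CCNS(N)(=O)=O)CC3)ncn2)cc1` has another core; how the two cores differ is not broken down here. In this assay compound 3 gives 56600 nM. Compound 4 `NS(=O)(=O)NCCC1CCN(c2cc(-c3ccc(Cl)cc3)ncn2)CC1` is still unmeasured and differs from compound 3 by chloro in place of methoxy on an aromatic carbon. This is the same kind of change as that from compound 1 to compound 2, not the same, since the earlier one sits ortho to a large group and this one para to a large group. The step expected is a 2.1-fold higher number from compound 3 to compound 4 (0.33 log units; beyond the scatter), resting on a 6.2-fold higher number from compound 1 to compound 2 (0.79 log units; beyond the scatter), kept smaller as the place differs. Compound 4 is therefore estimated at 120000 nM, expected between 40000 nM and 400000 nM.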

Compound 4, concentration for 50% growth inhibition: 19700 nM
Compound 4: middle estimate off by 6.1-fold (0.78 log units), on the high side; measured number outside the range, below it.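

In this assay, chloro in place of methoxy now gives a 2.9-fold lower number from compound 3 to compound 4 (0.46 log units; beyond the scatter), which runs opposite to the earlier step, so the effect of this change did not carry from one core to the other: the same change on two cores in this assay, a 6.2-fold higher number (0.79 log units; beyond the scatter) from compound 1 to compound 2 and a 2.9-fold lower number (0.46 log units; beyond the scatter) from compound 3 to compound 4, 18-fold (1.25 log units) apart, beyond the scatter of two such steps

The two pairs differ in their core and also in the place of the change, which here is para to a large group and in the earlier pair is elsewhere on the ring. These four compounds therefore cannot show whether the core, the place or both reverse the step, and they do not explain the reversal.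

Still open, going by these compounds, is how a 4-methoxyphenyl and a 4-chlorophenyl compare on the core of compound 1, a comparison that would separate place from core. Also open, on these data alone, is whether fluoro or methyl at this place would follow chloro.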